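Adding a fluorine to the anilino ring of compound 1

The source may hold more compounds than are shown below. What is called first, only, known or untested is meant among the compounds shown, and "the series" means these compounds.

Compound 1, with the structure `C=C1[C@@H](OC(C)=O)C[C@@H]2[C@](C)(CO[Si](C)(C)C(C)(C)C)[C@H](OC(C)=O)CC[C@@]2(C)[C@@H]1C[C@@H](Nc1ccccc1)C1=CCOC1=O`, gives 4840 nM in a functional assay on MCF7 cells (Homo sapiens) for cytotoxicity, read by sulforhodamine B assay; on this read-out higher numbers stand for weaker inhibition and lower numbers for stronger inhibition. Among the three compounds measured so far it carries the lowest number. Compound 2, `C=C1[C@@H](OC(C)=O)C[C@@H]2[C@](C)(COC=O)[C@H](OC(C)=O)CC[C@@]2(C)[C@@H]1C[C@@H](Nc1ccc(Br)cc1)C1=CCOC1=O`, gives 11400 nM, and compound 3, `C=C1[C@@H](OC(C)=O)C[C@@H]2[C@](C)(COC=O)[C@H](OC(C)=O)CC[C@@]2(C)[C@@H]1C[C@@H](Nc1ccccc1)C1=CCOC1=O`, gives 26200 nM. The step of a 5.4-fold higher number from compound 1 to compound 3 (0.73 log units; beyond the scatter) shows how much the silicon-bearing group matters; the step of a 2.3-fold higher number from compound 2 to compound 3 (0.36 log units; beyond the scatter) shows that a bromo on the aromatic ring lowers the number.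

Compound 4, `C=C1[C@@H](OC(C)=O)C[C@@H]2[C@](C)(CO[Si](C)(C)C(C)(C)C)[C@H](OC(C)=O)CC[C@@]2(C)[C@@H]1C[C@@H](Nc1ccc(F)cc1)C1=CCOC1=O`, differs from compound 1 by a single change: fluoro in place of hydrogen on an aromatic carbon. Among the measured compounds shown here, the only measured step that speaks to a halogen on that ring is the one from compound 2 to compound 3, and it was modest. Fluoro is a different halogen from bromo, so the lesson carries only loosely, and the step expected for compound 4 is a 1.4-fold lower number from compound 1 to compound 4 (0.14 log units; within the scatter), a small lowering that may not pass beyond the scatter. Compound 4 is therefore estimated at 3500 nM, within a range from 1500 nM to 8000 nM.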

Compound 4, half-maximal inhibitory concentration: 4340 nM
Beside the measured number, compound 4's estimate is 1.2-fold (0.09 log units) below it, within the range that was stated.
By their numbers in this assay, from the lowest: compounds 4 and 1 (each within the scatter of the next); then compound 2; then compound 3.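

On the anilino ring, at the place para to a large group, swapping hydrogen for fluoro on the core of compound 1 leaves the cytotoxicity number in this assay within the scatter (a 1.1-fold lower number from compound 1 to compound 4 (0.05 log units; within the scatter)). The earlier halogen step involved bromo, on a core carrying a different group in place of the silicon-bearing one, and it lay beyond the scatter (a 2.3-fold higher number from compound 2 to compound 3 (0.36 log units; beyond the scatter)), so a halogen at this place does not always move the number beyond the scatter. No measurement at hand explains this difference between the two steps.

Still open, going by these compounds, is whether bromo would give a step beyond the scatter on the silicon-bearing core of compound 1, or fluoro on the core of compound 3. Also open, on these data alone, is what a methoxy, a nitrile or a carboxylic acid would do at this place on the ring.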